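This account rests on a few compounds, and the source may have more. Where it says the series, first, only, none or still open, it means among the compounds named here.

Measured compounds:
compound 1 `Cc1nc(-c2ccccc2)sc1C(=O)CSc1nc(-c2ccccc2)c(C#N)c(=O)[nH]1` gives 92.1% in a functional assay on U-87MG ATCC cells for antiproliferative activity against U-87 MG (Homo sapiens), read by MTT assay, with a stated time of 48 h, tested at 5 uM; a higher number here means a weaker effect of the compound at the concentration tested, a lower number a stronger effect
compound 2 `Cc1nc(-c2ccc(Cl)cc2)sc1C(=O)CSc1nc(-c2ccccc2)c(C#N)c(=O)[nH]1` gives 88.9% in this assay

Compound 1 stands with the higher of the two numbers, and compound 2 sits near it, the step from one to the other being a number 3.2 percentage points lower from compound 1 to compound 2 (within the scatter); that step came with chloro in place of hydrogen on an aromatic carbon. Compound 3 `Cc1nc(-c2ccccc2)sc1C(=O)CSc1nc(-c2ccc(Cl)cc2)c(C#N)c(=O)[nH]1` has not yet been measured in this assay. It differs from compound 1 by chloro in place of hydrogen on an aromatic carbon, the same kind of change as between compound 1 and compound 2, but on the other phenyl ring of the shared core. Among the measured compounds shown here, the one measured step that bears on it, a number 3.2 percentage points lower from compound 1 to compound 2 (within the scatter), was within the scatter, so no step beyond the scatter is expected in either direction. The estimate for compound 3 is 89%, with a range from 78% to 98%, a step of a number 3.1 percentage points lower from compound 1 to compound 3 (within the scatter).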

Compound 3, a percentage reported as activity, at one concentration (the size of the read-out at that concentration, not a potency): 90.9%
For compound 3 the middle estimate is 1.9 percentage points below the measured one, within the range that was stated.
By their numbers in this assay, from the lowest: compounds 2, 3 and 1 (each within the scatter of the next).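

In this assay, replacing hydrogen with chloro on the second phenyl ring of the shared core, para to a large group, gives a number 1.2 percentage points lower from compound 1 to compound 3 (within the scatter). Among the compounds shown here, until now, the only reading for this change came from the other phenyl ring, where it gave a number 3.2 percentage points lower from compound 1 to compound 2 (within the scatter); the new result shows that this position, too, takes a chloro without a change that can be read apart from the scatter. The change from phenyl to 4-chlorophenyl therefore leaves the read-out within the scatter on either ring, and nothing shown gives a reason for this.

The compounds shown leave open whether an amine or a carboxylic acid at this position would give a step beyond the scatter. They also leave open whether chloro on both phenyl rings together would do so.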